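The source may hold more compounds than are shown below. What is called first, only, known or untested is meant among the compounds shown, and "the series" means these compounds.

Working notes on the cinnamate ester series.

The set holds three measured compounds that share the cinnamate ester glycolamide core. Compound 1 `COCOc1cc(/C=C/C(=O)OCC(=O)NCc2ccco2)ccc1OCc1ccccc1` carries the methoxymethoxy and benzyloxy pattern on the aryl ring with a (furan-2-yl)methyl amide. In a functional assay on BEL-7404 cells (Homo sapiens) for cytotoxicity, read by MTT assay, with a stated time of 72 h (on this read-out lower numbers stand for stronger inhibition and higher numbers for weaker inhibition), compound 1 reaches only the limit of the assay, > 200000 nM. Within the data shown here, compound 2 `COc1ccc(/C=C/C(=O)OCC(=O)Nc2ccc(Cl)cc2)cc1OC` is the one member with a number in this assay and gives 120000 nM. Compound 3 `COc1ccc(NC(=O)COC(=O)/C=C/c2cc(OC)c(OCc3ccccc3)c(OC)c2)cc1` also returns only a limit in this assay, > 200000 nM. Compound 1 therefore stands at the limit of > 200000 nM in this assay, at which 2 of the 3 values shown sit, and nothing in the measured set separates it from compound 3; compound 2 alone sits at a number, close to that limit.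

Among the measured compounds shown here, no pair of measured compounds differs in one place, so no measured step can be read. For the measured compounds named here, compound 4 `COCOc1cc(/C=C/C(=O)OCC(=O)Nc2nccs2)ccc1OCc1ccccc1` is the one change of interest from compound 1: 1,3-thiazol-2-yl in place of (furan-2-yl)methyl on an amide-type nitrogen. The expected step from compound 1 to compound 4 in this assay is an at least 1.1-fold lower number from compound 1 to compound 4 (0.04 log units; that floor lies within the scatter), no shift beyond the scatter, with a fair chance of another limit. Compound 4 is estimated at 180000 nM, within 60000 nM to 400000 nM.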

Compound 4, half-maximal inhibitory concentration: 130000 nM
For compound 4 the middle estimate is 1.4-fold (0.14 log units) above the measured one, within the range that was stated.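

Among these compounds, on the amide-type nitrogen, 1,3-thiazol-2-yl in place of (furan-2-yl)methyl gives the first readable step in this assay: an at least 1.5-fold lower number from compound 1 to compound 4 (0.18 log units; that floor lies within the scatter). From the compounds shown here alone, compound 1 stands at a limit, so this step is only a floor; its true size remains unknown, and the change need not exceed the usual scatter. The limit still holds a large share of the set: the limit of > 200000 nM in this assay, at which 2 of the 4 values shown sit.

The compounds shown leave open whether the ring itself or the loss of the linking carbon carries the step, a question that (1,3-thiazol-2-yl)methyl in the same place would address. Also open, going by these compounds, is how a carboxylic acid or an aliphatic amine on this side chain would read in this assay, and whether any such change moves the number clearly beyond the scatter.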